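Moving a Methyl Along the Amino Chain

The source may report more compounds than this note shows. Statements on the series, on what has been measured and on what is new or still open speak of the compounds shown alone.

Compound 2 `CCCNc1nnc(SCC(=O)N(Cc2cccc([N+](=O)[O-])c2)c2ccc(F)cc2)s1` is one of two compounds tested in an assay on isolated protein for inhibition of Amine oxidase [flavin-containing] A (Homo sapiens), read by fluorescence and Amplex Red, with a stated time of 30 min, tested at 1 nM; a higher number here means a stronger effect of the compound at the concentration tested, a lower number a weaker effect. Compound 2 gives 20.5% and stands highest of the two numbers, though the gap to compound 1 `CCCCNc1nnc(SCC(=O)N(Cc2cccc([N+](=O)[O-])c2)c2ccc(F)cc2)s1`, which gives 19.7%, is within the scatter. Compound 3 `CC(C)CNc1nnc(SCC(=O)N(Cc2cccc([N+](=O)[O-])c2)c2ccc(F)cc2)s1` differs from compound 2 by methyl in place of hydrogen on a saturated chain carbon bound to two saturated chain carbons. For the measured compounds named here, the only step measured, a number 0.8 percentage points higher from compound 1 to compound 2 (within the scatter), likewise changed a methyl on this chain and stayed within the scatter; on that basis no step beyond the scatter is expected in this assay. Compound 3 is expected to give 20%, between 8% and 32%, the estimated step being a number 0.5 percentage points lower from compound 2 to compound 3 (within the scatter).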

Compound 3, a percentage reported as inhibition, at one concentration (the size of the read-out at that concentration, not a potency): 17.3%
Compound 3: middle estimate off by 2.7 percentage points, on the high side, within the range that was stated.
By their numbers in this assay, from the lowest: compounds 3, 1 and 2 (each within the scatter of the next).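

In this assay, a branch on the chain gives a number 3.2 percentage points lower from compound 2 to compound 3 (within the scatter), and isopropyl in place of propyl gives a number 2.4 percentage points lower from compound 1 to compound 3 (within the scatter). Among these three compounds, then, neither a change in chain length nor a branch moves the reading beyond the scatter. No measurement shown here offers an explanation for this result. Going by these compounds, all three chains are saturated carbon groups, so it remains open whether a cyclohexyl ring, a carboxylic acid or an amine at this position would shift the number. A reading at one concentration also shows only the size of the effect at that concentration and leaves open whether any of these compounds would have a stronger or weaker effect at another concentration.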